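Sulfonyl substituent survey on a shared piperidinyl-piperidine core

A few compounds are considered here, and "the series" means these few. Any claim that something is new, unique, unknown or untested is made for them only; others in the source may bear on it.

Measured compounds:
- compound 1 `Cc1noc(C)c1S(=O)(=O)N1CCC(N2CCC(C)CC2)CC1`: in a functional assay on DLD-1 cells (Homo sapiens) for antiproliferative activity, read by CellTiter-Glo, with a stated time of 72 h (a higher number here means a weaker inhibitor, a lower number a stronger inhibitor), compound 1 gives > 5000 nM, a limit of the assay.
- compound 2 `CC1CCN(C2CCN(S(=O)(=O)c3cccnc3F)CC2)CC1`: in this assay compound 2 gives > 5000 nM, again a limit.
- compound 3 `CC1CCN(C2CCN(S(=O)(=O)c3nccn3C)CC2)CC1`: in this assay compound 3 gives > 5000 nM, also a limit.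

Compound 3 thus stands at the same limit as the other two; all three values sit there (the limit of > 5000 nM in this assay, at which 3 of the 3 values shown sit). Going by the values given here, none of the measured steps can be read: a step that the two limits leave unreadable from compound 1 to compound 2, a step that the two limits leave unreadable from compound 1 to compound 3 and a step that the two limits leave unreadable from compound 2 to compound 3.

Compound 4 `CC1CCN(C2CCN(S(=O)(=O)c3ccc(Br)c(Cl)c3)CC2)CC1` differs from compound 3 by 4-bromo-3-chlorophenyl in place of 1-methyl-1H-imidazol-2-yl on a sulfonyl sulfur. Among the compounds with values here, no measured step bears on this change, and the three limits give no direction. The expectation is therefore a step that the limit leaves unreadable from compound 3 to compound 4 in this assay, with a limit the most probable outcome. Compound 4 is estimated at 6000 nM, within 1500 nM to 20000 nM.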

Compound 4, half-maximal inhibitory concentration: 12 nM
The estimate for compound 4 lay 500-fold (2.70 log units) above the measured number; measured number below the stated range.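

The sulfonyl sulfur position is not flat: in this assay, 4-bromo-3-chlorophenyl gives an at least 410-fold lower number from compound 3 to compound 4 (2.61 log units; beyond the scatter), with an at least 410-fold lower number from compound 2 to compound 4 (2.61 log units; beyond the scatter) and an at least 410-fold lower number from compound 1 to compound 4 (2.61 log units; beyond the scatter). These sizes rest on limits, and the steps among compounds 1, 2 and 3 cannot be read. Compound 4 alone gives a number, and compound 2, which also carries a halogen, goes against any simple halogen pattern: the limit of > 5000 nM in this assay, at which 3 of the 4 values shown sit.

Still open, going by these compounds, is which part of the group carries the step: the bromine, the chlorine or the carbon-only ring. Plain phenyl, or a phenyl carrying only bromine or only chlorine, would separate these.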